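The compounds below may be only part of what the source reports. "The series", "measured", "known", "first", "only" and "open" are said of these compounds alone.

Compound 1 `Nc1nc(N)c2c(-c3ccsc3)cn([C@@H]3O[C@H](CO)[C@@H](O)[C@H]3O)c2n1` in a functional assay on K562 cells (Homo sapiens), read by MTT assay, with a stated time of 72 h (on this read-out lower numbers stand for stronger inhibition and higher numbers for weaker inhibition), gives > 20000 nM, which is a limit of the assay and not a number.
Compound 2 `COc1ncnc2c1c(-c1ccccc1)cn2[C@@H]1O[C@H](CO)[C@@H](O)[C@H]1O` in this assay gives > 20000 nM, again a limit rather than a number.
Compound 3 `CNc1ncnc2c1c(-c1ccsc1)cn2[C@@H]1O[C@H](CO)[C@@H](O)[C@H]1O` in this assay gives > 20000 nM, also a limit rather than a number.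

None of the three measured compounds shows a measurable inhibition of these cells: every value sits at the limit of > 20000 nM in this assay, at which 3 of the 3 values shown sit. Compound 3 therefore stands where the other two stand, at the edge of what this assay can report, with no number to rank it against compound 1 or compound 2.

Compound 4 `CNc1ncnc2c1c(-c1ccccc1)cn2[C@@H]1O[C@H](CO)[C@@H](O)[C@H]1O` has not yet been tested. It differs from compound 3 in one place: phenyl in place of thiophen-3-yl on an aromatic carbon. The shared core and the sugar are kept. Within the data shown here, since the only value available for compound 3 is a limit, no step between measured compounds can be drawn on, and the change itself gives no basis to expect a swing beyond the scatter in either direction; the estimated step that the limit leaves unreadable from compound 3 to compound 4 is expected to be essentially none. Compound 4 is accordingly expected to give about 30000 nM, within 15000 nM to 100000 nM, most likely reported again only as a limit.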

Compound 4, half-maximal inhibitory concentration: > 20000 nM
Compound 4 was reported as a limit; the forecaster's own chance of this, stated with the estimate: 85%; the middle value is on the limit's open side.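

No step can be read from compound 3 to compound 4 or from compound 2 to compound 4, because all of these compounds stop at the same limit: the limit of > 20000 nM in this assay, at which 4 of the 4 values shown sit.

From the compounds shown here alone, whether phenyl, thiophen-3-yl, methylamino or methoxy makes any difference to inhibition of these cells stays open.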